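A few compounds are considered here, and "the series" means these few. Any claim that something is new, unique, unknown or untested is made for them only; others in the source may bear on it.

Working notes on the series. Compound 1 `O=C(Nc1ccccc1)Nc1nnc(Sc2ncnc3scc(-c4ccncc4)c23)s1` gives 23300 nM in a functional assay on T47D cells (Homo sapiens) for antiproliferative activity, read by MTT assay, with a stated time of 48 h; a lower number here means a stronger inhibitor, a higher number a weaker inhibitor. Within the data shown here, compound 2 `Cc1ccc(NC(=O)Nc2nnc(Sc3ncnc4scc(-c5ccncc5)c34)s2)cc1Cl` gives 34800 nM in this assay, the higher of the two numbers so far, though the step of a 1.5-fold higher number from compound 1 to compound 2 (0.17 log units; within the scatter) is within the scatter, so no order between the two can be read.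

Compound 3 `Cc1ccc(NC(=O)Nc2nnc(Sc3ncnc4scc(-c5ccncc5)c34)s2)cc1` has not yet been measured in this assay. It differs from compound 2 by hydrogen in place of chloro on an aromatic carbon; cut one bond further out, this reads as 3-chloro-4-methylphenyl to 4-methylphenyl on the urea-type nitrogen. Among the measured compounds shown here, the only measured step that bears on it is the aryl change a 1.5-fold higher number from compound 1 to compound 2 (0.17 log units; within the scatter), which was within the scatter; compound 3 sits between compound 1 and compound 2 in that respect. The expectation for this assay is therefore no step beyond the scatter, a 1.2-fold lower number from compound 2 to compound 3 (0.09 log units; within the scatter). Compound 3 is estimated at 28000 nM, range 12000 nM to 70000 nM.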

Compound 3, half-maximal inhibitory concentration: 17800 nM
Estimate against measurement, compound 3: 1.6-fold (0.20 log units) above; the range from low to high includes it.
By their numbers in this assay, from the lowest: compounds 3, 1 and 2 (each within the scatter of the next).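

Hydrogen in place of chloro on the aromatic carbon ortho to a methyl group gives a 2.0-fold lower number from compound 2 to compound 3 (0.29 log units; within the scatter) in this assay and therefore shows no effect of the chloro group that can be separated from the scatter. Methyl in place of hydrogen on an aromatic carbon gives a 1.3-fold lower number from compound 1 to compound 3 (0.12 log units; within the scatter) and likewise shows no readable effect, so no order can be read among phenyl, 4-methylphenyl and 3-chloro-4-methylphenyl on the urea-type nitrogen. No measurement is at hand that bears on the reason for these small steps.

The compounds shown leave open whether another group on this aromatic ring, such as an amine, a carboxylic acid or a longer alkyl chain, would give a step beyond the scatter. From the compounds shown here alone, since only the aryl group varies, what a change in the shared core would do also stays open.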